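The source may hold more compounds than are shown below. What is called first, only, known or untested is meant among the compounds shown, and "the series" means these compounds.

Measured so far in a functional assay on HL-60 cells (Homo sapiens) for cytotoxicity, read by MTT assay, with a stated time of 72 h; a higher number here means a weaker inhibitor, a lower number a stronger inhibitor:
compound 1 `Fc1ccc(-c2nnc3nnc(N4CCCC4)n3n2)cc1` gives 4560 nM.
compound 2 `C1CCC(c2nnc3nnc(N4CCCC4)nn23)CC1` gives 23800 nM.
compound 3 `c1ccc(-c2nnc3nnc(N4CCCC4)n3n2)cc1` gives only a limit of the assay, > 100000 nM.

Compound 2 stands highest of the two numbers in this assay; compound 1 gives a lower number, a gap beyond the scatter. Not yet measured is compound 4 `CCc1nnc2nnc(N3CCCC3)nn12`. It differs from compound 2 by ethyl in place of cyclohexyl on an aromatic carbon. Among the compounds with values here, the only measured single change is an at least 21-fold higher number from compound 1 to compound 3 (1.34 log units; beyond the scatter). That step concerns a substituent on the aryl group, not the group carried by compound 2, so it does not bear directly on the step to compound 4. The value of compound 3 sits at the limit of > 100000 nM in this assay, at which 1 of the 3 values shown sits. Nothing measured shows how the number moves when the group at this position shrinks from a ring to a chain. Compound 4 is expected at about 40000 nM, range 10000 nM to 150000 nM, meaning a 1.7-fold higher number from compound 2 to compound 4 (0.23 log units; within the scatter).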

Compound 4, half-maximal inhibitory concentration: 47000 nM
The estimate for compound 4 lay 1.2-fold (0.07 log units) below the measured number; low and high end bracket the measured number.
By their numbers in this assay, from the lowest: compound 1; then compounds 2 and 4 (each within the scatter of the next). At a limit, above all of these: compound 3.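

In this assay, within the data shown here, the swap of cyclohexyl for ethyl on this aromatic carbon gives a 2.0-fold higher number from compound 2 to compound 4 (0.30 log units; within the scatter) and is the first step read at this position. With compound 2 and compound 4 within the scatter of each other, the six-membered ring is not required to hold the number at this level, and the position tolerates this loss of carbon atoms. No measurement shown gives a reason for this outcome. Going by these compounds, whether an amine or a carboxylic acid here would move the number beyond the scatter stays open, as does the effect of a longer chain such as butyl.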